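Cytotoxicity notes on a nucleoside series: compound 4

This account rests on a few compounds, and the source may have more. Where it says the series, first, only, none or still open, it means among the compounds named here.

Three compounds of the series have been run in an ADME assay on MRC5 cells (Homo sapiens), read by MTT assay, with a stated time of 72 h; on this read-out lower numbers stand for stronger inhibition and higher numbers for weaker inhibition. Compound 1 `Nc1nc2c(c(-c3ccccc3)cn2[C@@H]2O[C@H](CO)[C@@H](O)[C@H]2O)c(=O)[nH]1` gives only a limit, > 100000 nM. Compound 3 `O=c1[nH]cnc2c1c(-c1ccoc1)cn2[C@@H]1O[C@H](CO)[C@@H](O)[C@H]1O` likewise gives only a limit, > 100000 nM. Within the data shown here, compound 2 `Cc1nc(N)c2c(-c3cc4ccccc4o3)cn([C@@H]3O[C@H](CO)[C@@H](O)[C@H]3O)c2n1` is the one compound with a number, 91800 nM, so it is the only measured point against which a new compound can be set. Among the measured compounds shown here, no step between two measured compounds is available, because two of the three values sit at the limit of > 100000 nM in this assay, at which 2 of the 3 values shown sit.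

Compound 4 `Cc1nc(N)c2c(I)cn([C@@H]3O[C@H](CO)[C@@H](O)[C@H]3O)c2n1` carries iodo in place of 1-benzofuran-2-yl on an aromatic carbon. Given that compound 2 gives 91800 nM and the two other compounds reach no number at all, the expected step in this assay from compound 2 to compound 4 is a 1.1-fold higher number from compound 2 to compound 4 (0.04 log units; within the scatter), nothing beyond the scatter in either direction. Compound 4 is therefore expected to give 100000 nM, between 40000 nM and 250000 nM, with a real chance that only a limit is reported.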

Compound 4, half-maximal inhibitory concentration: 85800 nM
Compound 4: middle estimate off by 1.2-fold (0.07 log units), on the high side; the measured number falls inside the stated range.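

Among these compounds, at the aromatic carbon two ring bonds from the ring nitrogen, the one readable step in this assay is a 1.1-fold lower number from compound 2 to compound 4 (0.03 log units; within the scatter), with iodo in place of 1-benzofuran-2-yl. Across this pair, exchanging a group of two aromatic rings and 9 heavy atoms for a single iodine atom leaves the values within the scatter of each other, so this change shows no effect on the read-out. Both values lie close to the top of the measurable range, which leaves little room for a weakening step to show: the limit of > 100000 nM in this assay, at which 2 of the 4 values shown sit.

On these data alone, whether an amine, a carboxylic acid or a longer chain at this position would give a clearly lower number than compound 2 and compound 4 stays open. Steps involving compound 1 and compound 3 cannot be read.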